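The source may hold more compounds than are shown below. What is called first, only, known or untested is meant among the compounds shown, and "the series" means these compounds.

Of the compounds shown here, three sharing one core have been read in a physicochemical assay for solubility, at pH 7.9; on this read-out lower numbers stand for lower solubility and higher numbers for higher solubility: compound 1 `O=c1c(-c2ccc(F)cc2)cn(C2CC2)c2cc(N3CCNCC3)c(F)cc12`, compound 2 `O=c1c(-c2ccc(Cl)cc2)cn(C2CC2)c2cc(N3CCNCC3)c(F)cc12` and compound 3 `O=c1c(-c2cccc(F)c2)cn(C2CC2)c2cc(N3CCNCC3)c(F)cc12`. Compound 3 gives > 400000 nM, which is a limit of the assay and not a number. Compound 1 gives > 400000 nM, again a limit. Compound 2 gives > 400000 nM, also a limit. The whole picture so far is the limit of > 400000 nM in this assay, at which 3 of the 3 values shown sit, so compound 3 has no exact place among the others.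

Compound 4 `O=c1c(-c2cccc(Cl)c2)cn(C2CC2)c2cc(N3CCNCC3)c(F)cc12` keeps all of compound 3 except one atom, with chloro in place of fluoro on an aromatic carbon, meta to a large group (chloro in place of fluoro on an aromatic carbon). Going by the values given here, the nearest precedent is the same swap in the 4-fluorophenyl compound, which gives a step that the two limits leave unreadable from compound 1 to compound 2. Moving the fluoro gives a step that the two limits leave unreadable from compound 1 to compound 3, and the remaining pair gives a step that the two limits leave unreadable from compound 2 to compound 3. None of these steps has a size that can be used. Compound 2, the 4-chlorophenyl compound, still gives > 400000 nM, a limit, so no step beyond the usual scatter is expected for the swap in compound 4, and a reading at the same limit is likely. The expected step is a number no higher from compound 3 to compound 4 (the limit leaves the size open). For compound 4 the estimated value is 400000 nM, with an expected range from 200000 nM to 800000 nM.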

Compound 4, solubility: > 400000 nM
Compound 4 ended at the assay's limit; the forecaster's own chance of this, stated with the estimate: 85%; the middle value sits exactly at the limit.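

In this assay, the steps linking compound 4 to compound 1, compound 2 and compound 3 cannot be read, and all four compounds share one reading: the limit of > 400000 nM in this assay, at which 4 of the 4 values shown sit. The compounds shown leave open how far each true solubility lies past that limit, and whether fluoro against chloro, or 3-chlorophenyl against 4-chlorophenyl, makes any difference.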